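The source may report more compounds than this note shows. Statements on the series, on what has been measured and on what is new or still open speak of the compounds shown alone.

Among the compounds with values here, in a functional assay on KB cells (Homo sapiens) for cytotoxicity, read by MTT assay, with a stated time of 72 h (on this read-out higher numbers stand for weaker inhibition and lower numbers for stronger inhibition), compound 1 `Cc1ccc(S(=O)(=O)c2nc3ccccc3nc2Nc2ccccc2)cc1` is the only compound with a number so far, at 19000 nM. Compound 2 `COc1cc(Nc2nc3ccccc3nc2S(=O)(=O)c2ccc(C)cc2)cc(OC)c1` has no place on that scale, since the entry for compound 2 reads "not determined" (no result reported). The entry for compound 3 `COc1cc(Nc2nc3ccccc3nc2S(=O)(=O)c2ccc(C)cc2)cc(OC)c1OC` is the same: for compound 3 it reads "not determined" (no result reported). Nothing can therefore be ranked against compound 2.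

Compound 4 `Cc1ccc(S(=O)(=O)c2nc3ccccc3nc2Nc2ccc(C(F)(F)F)cc2)cc1` keeps the shared core of compound 2 and changes one group: 4-(trifluoromethyl)phenyl in place of 3,5-dimethoxyphenyl on a nitrogen on an aromatic ring. Within the data shown here, with no measured starting point, the size of this step cannot be read from the data, and no step between measured compounds offers a guide. Among the measured compounds shown here, the only anchor is compound 1 at 19000 nM. In this assay, compound 4 is therefore expected to land in the same region, with at most a modest shift towards stronger inhibition and little beyond the usual scatter. The estimated value for compound 4 is 13000 nM, with an expected range from 4000 nM to 40000 nM.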

Compound 4, half-maximal inhibitory concentration: 10300 nM
For compound 4 the middle estimate is 1.3-fold (0.10 log units) above the measured one; the range from low to high includes it.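

Within the data shown here, compound 4 gives the first step that can be read at this position: in this assay, placing trifluoromethyl on an aromatic carbon of the phenyl group, where compound 1 has hydrogen, gives a 1.8-fold lower number from compound 1 to compound 4 (0.27 log units; within the scatter). The two numbers therefore cannot be told apart, so this single change on the phenyl group shows no clear effect on the read-out. Nothing measured here offers an explanation for this result.

Steps involving compound 2 or compound 3 cannot be read, since neither compound has a number, so the effect of methoxy groups on the phenyl ring remains unknown. Also open, from the compounds shown here alone, is whether a different group in the place of trifluoromethyl, such as an amine or a carboxylic acid, would shift the number beyond the usual scatter.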